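The compounds below may be only part of what the source reports. "The series", "measured", "known", "first", "only" and "open" are said of these compounds alone.

In a functional assay on the whole organism (strain Sprague-Dawley) for inhibition, with Rattus norvegicus as the target, read by paw edema, with a stated time of 180 min, at a dose of 30 mg/kg by the oral route (on this read-out lower numbers stand for a weaker effect and higher numbers for a stronger effect at the one dose given), compound 3 `COc1ccnc(CNc2ccc3[nH]c(C)nc3c2)c1C` gives 55%, the lowest of the three numbers at hand. Compound 2 `COc1ccnc(CNc2ccc3c(c2)nc(C)n3C[C@@H](O)[C@H]2O[C@H](O)[C@@H](O)[C@H]2O)c1C` gives 58% in this assay, a number within the scatter of compound 3, whereas compound 1 `COc1ccnc(CNc2ccc3c(c2)nc(C)n3C[C@@H](O)[C@H]2O[C@H](O)[C@@H](O)[C@H]2O)c1OC` gives 72% in this assay, a number that stands beyond the scatter above compound 3. Among the measured compounds shown here, the one measured step of a single change, a number 14 percentage points lower from compound 1 to compound 2 (beyond the scatter), concerns methyl in place of methoxy on an aromatic carbon. Compound 4 `COc1c(C)cnc(CNc2ccc3[nH]c(C)nc3c2)c1C` differs from compound 3 by methyl in place of hydrogen on an aromatic carbon, the new group sitting ortho to a methoxy group and two atoms from the ring nitrogen. For the measured compounds named here, no measured step puts a methyl where a hydrogen stood, so that one modest step bears on compound 4 only loosely and sets no direction for it. Compound 4 is therefore expected to show no change at the digits printed from compound 3 to compound 4 (within the scatter), that is, no step beyond the scatter. The estimate for compound 4 in this assay is 55%, with a range from 35% to 75%.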

Compound 4, a percentage reported as inhibition, in the whole organism at one dose (the size of the read-out at that dose, not a potency): 53%
Compound 4: middle estimate off by 2 percentage points, on the high side; the range from low to high includes it.
By their numbers in this assay, from the lowest: compounds 4, 3 and 2 (each within the scatter of the next); then compound 1.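

In this assay, the added methyl gives a number 2 percentage points lower from compound 3 to compound 4 (within the scatter). Among the compounds shown here, this is the first measured step at this position, an aromatic carbon ortho to a methoxy group and two atoms from the ring nitrogen, and it shows that a methyl can replace hydrogen here without moving the number beyond the scatter at the one dose given; the single earlier step, methyl in place of methoxy, could not show this. No measurement at hand offers an explanation for this result.

On these data alone, whether an amine or a carboxylic acid on this same carbon would leave the number as little changed remains open. So does whether this methyl would give the same result on the larger core of compound 1, and whether the result would hold at other doses.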